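Swapping the aryl group on the oxazole core for a carbamoylpyridine

A few compounds are considered here, and "the series" means these few. Any claim that something is new, unique, unknown or untested is made for them only; others in the source may bear on it.

Measured compounds:
Compound 1 `COc1ccccc1-c1cnc(C(=O)CCCCCCc2ccccc2)o1` gives 400 nM in an assay (Rattus norvegicus) for inhibition of Fatty-acid amide hydrolase 1 (Homo sapiens); on this read-out lower numbers stand for stronger inhibition and higher numbers for weaker inhibition.
Compound 2 `N#Cc1ccccc1-c1cnc(C(=O)CCCCCCc2ccccc2)o1` gives 130 nM in this assay.
Compound 3 `O=C(CCCCCCc1ccccc1)c1ncc(-c2ccc(O)cc2)o1` gives 140 nM in this assay.

Compound 1 has the highest number of the three, so it is the weakest inhibitor here. Compound 4 `NC(=O)c1cccc(-c2cnc(C(=O)CCCCCCc3ccccc3)o2)n1` differs from it in one place: 6-carbamoylpyridin-2-yl in place of 2-methoxyphenyl on an aromatic carbon. Among the compounds with values here, two measured steps bear on this change, both replacing the 2-methoxyphenyl or its methoxy with a more polar partner: a 3.1-fold lower number from compound 1 to compound 2 (0.49 log units; beyond the scatter) and a 2.9-fold lower number from compound 1 to compound 3 (0.46 log units; beyond the scatter). Both moved the number down by a modest amount. A similar modest fall is therefore expected for compound 4, giving a 2.7-fold lower number from compound 1 to compound 4 (0.43 log units; beyond the scatter). Compound 4 is estimated at 150 nM, with a likely range from 50 nM to 500 nM.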

Compound 4, inhibition constant: 1 nM
For compound 4 the middle estimate is 150-fold (2.18 log units) above the measured one, and the stated range ends above it.
By their numbers in this assay, from the lowest: compound 4; then compounds 2 and 3 (each within the scatter of the next); then compound 1.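

This position on the shared core can give far more than the earlier aryl changes showed: 6-carbamoylpyridin-2-yl brings a large fall (a 400-fold lower number from compound 1 to compound 4 (2.60 log units; beyond the scatter)), and the falls against the other two compounds are similarly large (a 140-fold lower number from compound 3 to compound 4 (2.15 log units; beyond the scatter); a 130-fold lower number from compound 2 to compound 4 (2.11 log units; beyond the scatter)). The earlier steps shown here were modest at most, so they gave no sign of a change this size. Nothing measured here explains the gain.

The ring nitrogen and the carbamoyl group enter together, so the compounds shown cannot tell which of them matters. A plain pyridin-2-yl group, or a phenyl carrying the carbamoyl group, would separate the two.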